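This account rests on a few compounds, and the source may have more. Where it says the series, first, only, none or still open, it means among the compounds named here.

Among the compounds with values here, in a functional assay on MGC-803 cells (Homo sapiens) for inhibition, read by MTT assay, with a stated time of 48 h (a higher number here means a weaker inhibitor, a lower number a stronger inhibitor), compound 1 `COC(=O)c1cc(CNc2cc(OC)c(OC)c(OC)c2)ccc1OC` gives 49600 nM, the only actual number measured so far, and a high number on this scale marks a weak inhibitor. Compound 2 `COc1cc(NCc2ccc(C)cc2)cc(OC)c1OC` is recorded at > 80000 nM, which is a limit of the assay and not a number.

Compound 3 `COc1ccc(CNc2cc(OC)c(OC)c(OC)c2)cc1N` keeps the core of compound 1 and changes one place: amino in place of methoxycarbonyl on an aromatic carbon. In plain terms, this puts amino in place of methoxycarbonyl on an aromatic carbon, ortho to a methoxy group. Within the data shown here, no measured step shows what this swap does, so any forecast is loose. A moderate gain in strength is expected, with room for a result close to compound 1 at 49600 nM. The estimated size of the change is a 4.1-fold lower number from compound 1 to compound 3 (0.62 log units; beyond the scatter). For compound 3, the estimated value is 12000 nM, within an expected range of 1000 nM to 70000 nM.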

Compound 3, half-maximal inhibitory concentration: 7970 nM
For compound 3 the middle estimate is 1.5-fold (0.18 log units) above the measured one; the measured number falls inside the stated range.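

Placing amino in place of methoxycarbonyl on this aromatic carbon, ortho to a methoxy group, gives a 6.2-fold lower number from compound 1 to compound 3 (0.79 log units; beyond the scatter) in this assay, so this single place clearly affects the result, though the step is modest. The swap changes several things at once: the entering amino group is smaller than methoxycarbonyl and brings a hydrogen-bond donor that methoxycarbonyl lacks, and this one pair cannot separate those differences. Compound 2 adds no number to this picture, as its entry is a limit of the assay and not a measured value: the limit of > 80000 nM in this assay, at which 1 of the 3 values shown sits.

Going by these compounds, it remains open whether the gain comes from having amino at this place or simply from losing methoxycarbonyl. A hydroxyl group, a carboxylic acid or an acetamide on the same carbon would help to separate these two readings.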